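This account rests on a few compounds, and the source may have more. Where it says the series, first, only, none or still open, it means among the compounds named here.

Measured so far:
Compound 1 `COc1ccc(/C=C/C(=O)c2ccc(OC)c3c2OC(C)(C)C=C3)cc1O`: 630 nM
Compound 2 `COc1ccc(/C=C/C(=O)c2ccc(OC)c3c2OC(C)(C)C=C3)cc1OCC=C(C)C`: > 10000 nM
Compound 3 `C=CCOc1cc(/C=C/C(=O)c2ccc(OC)c3c2OC(C)(C)C=C3)ccc1OC`: > 10000 nM

Among the compounds with values here, in a functional assay on K562 cells (Homo sapiens) for cytotoxicity, read by MTT assay (on this read-out higher numbers stand for weaker inhibition and lower numbers for stronger inhibition), compound 1 gives 630 nM, the only number in the set. Compound 2 sits at the limit of the assay > 10000 nM. Compound 3 likewise sits at the limit of the assay > 10000 nM. Replacing the phenolic hydrogen of compound 1 therefore reads as a large move toward weaker inhibition twice over: an at least 15-fold higher number from compound 1 to compound 2 (1.20 log units; beyond the scatter) with 3-methylbut-2-en-1-yl in place of hydrogen on an oxygen on an aromatic ring, and an at least 15-fold higher number from compound 1 to compound 3 (1.20 log units; beyond the scatter) with allyl in place of hydrogen on the same oxygen. The comparison of the two alkylated compounds, a step that the two limits leave unreadable from compound 2 to compound 3, cannot be read because the limit of > 10000 nM in this assay, at which 2 of the 3 values shown sit, holds both of their values.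

Compound 4 `C=CC(=O)Oc1cc(/C=C/C(=O)c2ccc(OC)c3c2OC(C)(C)C=C3)ccc1OC` is the next step from compound 1: vinylcarbonyl in place of hydrogen on an oxygen on an aromatic ring. It again removes the hydrogen that both measured steps removed, so a step in the same direction, toward weaker inhibition, is expected: a 6.3-fold higher number from compound 1 to compound 4 (0.80 log units; beyond the scatter). The two measured steps were both large, and compound 4 is expected to land near or at the limit, with a real chance that only a limit is reported. For compound 4 the estimate in this assay is 4000 nM, within a range of 800 nM to 20000 nM.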

Compound 4, half-maximal inhibitory concentration: 300 nM
For compound 4 the middle estimate is 13-fold (1.12 log units) above the measured one; measured number below the stated range.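

In this assay, removing the hydrogen on this oxygen does not by itself weaken inhibition: vinylcarbonyl in place of that hydrogen gives a 2.1-fold lower number from compound 1 to compound 4 (0.32 log units; beyond the scatter), a modest change opposite in direction to those seen with the allyl and 3-methylbut-2-en-1-yl groups. The outcome at this position therefore depends on which group enters, with vinylcarbonyl in place of allyl giving an at least 33-fold lower number from compound 3 to compound 4 (1.52 log units; beyond the scatter) and vinylcarbonyl in place of 3-methylbut-2-en-1-yl giving an at least 33-fold lower number from compound 2 to compound 4 (1.52 log units; beyond the scatter). These two large steps are bounds rather than exact sizes, since compound 2 and compound 3 each stand at a limit: the limit of > 10000 nM in this assay, at which 2 of the 4 values shown sit.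

The step between compound 2 and compound 3 still cannot be read, so the two alkyl groups cannot be ranked against each other. On these data alone, whether the vinylcarbonyl result depends on the carbonyl or on its double bond stays open, and an acetyl or propanoyl group on the same oxygen would separate the two.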